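The compounds below may be only part of what the source reports. "The series", "measured", "known", "first", "only" and "open" are said of these compounds alone.

Measured so far:
Compound 1, `COc1ccc(N2C[C@@H](C)N[C@@H](C)C2)cc1NS(=O)(=O)c1ccc(-c2ccccn2)s1`: in a functional assay for agonist activity at growth hormone secretagogue receptor type 1 (Homo sapiens), read by FLIPR (on this read-out higher numbers stand for an effect only at larger amounts of compound and lower numbers for an effect already at smaller amounts), compound 1 gives 10 nM.
Compound 2, `CCOc1ccc(N2C[C@@H](C)N[C@@H](C)C2)cc1NS(=O)(=O)c1ccc(-c2ccccn2)s1`: in this assay compound 2 gives 39.8 nM.

Compound 2 stands at the higher of the two numbers; the nearest is compound 1, and the two are separated by a 4.0-fold higher number from compound 1 to compound 2 (0.60 log units; beyond the scatter), a step brought about by methyl in place of hydrogen on a saturated chain carbon bound to an oxygen on the aromatic ring.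

Compound 3, `C[C@@H]1CN(c2ccc(Cl)c(NS(=O)(=O)c3ccc(-c4ccccn4)s3)c2)C[C@H](C)N1`, has not yet been measured in this assay. It differs from compound 2 by chloro in place of ethoxy on an aromatic carbon. For the measured compounds named here, no measured step shows this exchange directly. Going by the values given here, the only step known, a 4.0-fold higher number from compound 1 to compound 2 (0.60 log units; beyond the scatter), concerns the same position on the ring but lengthens the group there rather than replacing it with chlorine, so it bears on the new step only loosely. It does show that the group at this position matters, and that the longer ethoxy of compound 2 gave the higher number. With the ethoxy gone, compound 3 is expected to show a step of a 2.7-fold lower number from compound 2 to compound 3 (0.42 log units; beyond the scatter), moving back toward the number of compound 1. The estimate for compound 3 is 15 nM, within a range from 4 nM to 60 nM.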

Compound 3, half-maximal effective concentration: 39.8 nM
The estimate for compound 3 lay 2.7-fold (0.42 log units) below the measured number; low and high end bracket the measured number.
By their numbers in this assay, from the lowest: compound 1; then compounds 2 and 3 (each within the scatter of the next).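

In this assay, putting chloro in place of ethoxy gives no change at the digits printed from compound 2 to compound 3 (within the scatter), so at this position the ethoxy group, with its 3 heavy atoms and its hydrogen-bond acceptor, can give way to a single chlorine atom without a change beyond the usual scatter. Set against the methoxy group, the same chlorine gives a 4.0-fold higher number from compound 1 to compound 3 (0.60 log units; beyond the scatter), which leaves compound 1 alone at the lowest number of the three and shows that the read-out does not simply follow the size of the group: chloro and ethoxy differ in heavy atoms yet cannot be told apart, while methoxy stands apart from both. Nothing available here explains why methoxy behaves differently from the other two groups.

What a fluoro, a methyl or an amino group would give at this same position remains open, so the three groups shown do not yet define what this position prefers. From the compounds shown here alone, it is also open whether the match between chloro and ethoxy would hold if the rest of the shared core were changed.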